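Chloro in Place of Methoxy: What to Expect for Compound 4

The source may hold more compounds than are shown below. What is called first, only, known or untested is meant among the compounds shown, and "the series" means these compounds.

Of the compounds shown here, three sharing one core have been measured in a functional assay on HT-29 cells (Homo sapiens) for cytotoxicity, read by MTT assay, with a stated time of 72 h; a lower number here means a stronger inhibitor of growth, a higher number a weaker inhibitor of growth. Compound 1 `COc1ccc(OC(=O)Nc2ccc([Se]C#N)cc2)cc1` gives 41500 nM. Compound 2 `CCCOC(=O)Nc1ccc([Se]C#N)cc1` gives 51900 nM, and compound 3 `CCCCCCOC(=O)Nc1ccc([Se]C#N)cc1` gives 40300 nM. The number for compound 1 sits between those of compounds 3 and 2, and all three lie within the scatter of one another, so none of them can be set apart from the rest. Within the data shown here, the only step between measured compounds that differ in one place is a 1.3-fold lower number from compound 2 to compound 3 (0.11 log units; within the scatter), a lengthening of the chain, and it stays within the scatter.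

Compound 4 `N#C[Se]c1ccc(NC(=O)Oc2ccc(Cl)cc2)cc1` differs from compound 1 by chloro in place of methoxy on an aromatic carbon. Among the measured compounds shown here, no measured step touches the ring that carries this change, so nothing bears on it directly; the one comparison available, a 1.3-fold lower number from compound 2 to compound 3 (0.11 log units; within the scatter), shows only that a change elsewhere left this assay unchanged within the scatter. Given that compound 1 gives 41500 nM, the series offers no ground for a shift in either direction. Compound 4 is therefore expected to show no step beyond the scatter, a 1.0-fold higher number from compound 1 to compound 4 (0.01 log units; within the scatter). Compound 4 is estimated at 42000 nM, with a range from 15000 nM to 120000 nM.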

Compound 4, concentration for total growth inhibition: 40300 nM
Beside the measured number, compound 4's estimate is 1.0-fold (0.02 log units) above it, and the stated range covers the measured number.
By their numbers in this assay, from the lowest: compounds 3, 4, 1 and 2 (each within the scatter of the next).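

In this assay, chloro in place of methoxy on an aromatic carbon, para to a large group, gives a 1.0-fold lower number from compound 1 to compound 4 (0.01 log units; within the scatter). Among these compounds, this is the first measured step at this position of the ring; until now the only step lay in the saturated chain of compound 2 and compound 3, at the other end of the shared core. It shows that at this position a methoxy, with two heavy atoms and one hydrogen-bond acceptor, can give way to a single chlorine with no hydrogen-bond acceptor while the number stays within the scatter, though no measurement given here accounts for this.

From the compounds shown here alone, one exchange at one position cannot say how far this tolerance extends, and whether an amine, a carboxylic acid or a longer chain in the same place would also leave the number within the scatter remains open. Going by these compounds, it also remains open whether chloro on another carbon of this ring, or a second chloro added to it, would give a step beyond the scatter in this assay.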